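Trifluoromethoxy in place of methyl on the distal ring

This account rests on a few compounds, and the source may have more. Where it says the series, first, only, none or still open, it means among the compounds named here.

Compound 1 `COC(=O)/C=C/c1cccc(N(Cc2ccc(/C=C/c3cccc(F)c3)cc2)C(=O)C(C)C)c1`: 71 nM in an assay on isolated protein with Bile acid receptor (Homo sapiens) as the target; a higher number here means that more compound is needed for the effect, a lower number that less compound is needed
Compound 2 `COC(=O)/C=C/c1cccc(N(Cc2ccc(-c3ccc(C)cc3)cc2)C(=O)C(C)C)c1`: 118 nM in this assay
Compound 3 `COC(=O)/C=C/c1cccc(N(Cc2ccc(-c3cccc(C)c3)cc2)C(=O)C(C)C)c1`: 163 nM in this assay

Compound 3 shows the highest number of the three; the step of a 1.4-fold higher number from compound 2 to compound 3 (0.14 log units; within the scatter) is within the scatter, while a 2.3-fold higher number from compound 1 to compound 3 (0.36 log units; beyond the scatter) is beyond it. Compound 4 `COC(=O)/C=C/c1cccc(N(Cc2ccc(-c3cccc(OC(F)(F)F)c3)cc2)C(=O)C(C)C)c1` differs from compound 3 by trifluoromethoxy in place of methyl on an aromatic carbon. Among the compounds with values here, none of the measured steps touches this change: a 1.7-fold higher number from compound 1 to compound 2 (0.22 log units; within the scatter), a 2.3-fold higher number from compound 1 to compound 3 (0.36 log units; beyond the scatter) and a 1.4-fold higher number from compound 2 to compound 3 (0.14 log units; within the scatter) all exchange the whole outer group, not a single substituent on the same ring. With no direct guide, compound 4 is expected to sit close to compound 3, with a step of a 1.1-fold lower number from compound 3 to compound 4 (0.04 log units; within the scatter) in this assay that is not confidently beyond the scatter. Compound 4 is estimated at 150 nM, within 60 nM to 400 nM.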

Compound 4, half-maximal effective concentration: 247 nM
Compound 4: middle estimate off by 1.6-fold (0.22 log units), on the low side; the measured number falls inside the stated range.
By their numbers in this assay, from the lowest: compounds 1, 2, 3 and 4 (each within the scatter of the next, the first and the last beyond it).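

Trifluoromethoxy in place of methyl gives a 1.5-fold higher number from compound 3 to compound 4 (0.18 log units; within the scatter) in this assay, so this position accepts the larger group with no change that can be told from the scatter. Larger differences appear only when the whole outer group is exchanged, as in a 2.1-fold higher number from compound 2 to compound 4 (0.32 log units; beyond the scatter) and a 3.5-fold higher number from compound 1 to compound 4 (0.54 log units; beyond the scatter). No supporting measurement bears on the reason for these steps.

As far as these compounds go, whether an amine or a carboxylic acid at this position would move the number remains open. So does whether trifluoromethoxy in place of the methyl of 4-methylphenyl would give a similar step.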